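Piperazine benzyl substituent series: aryl for methylsulfonyl

The compounds below may be only part of what the source reports. "The series", "measured", "known", "first", "only" and "open" are said of these compounds alone.

Measured so far:
compound 1, `COC1(Cc2ccccc2C)CCN(c2ccc(C(=O)NS(=O)(=O)c3ccc(N[C@H](CCN(C)C)CSc4ccccc4)c([N+](=O)[O-])c3)cc2)CC1`, 1.4 nM
compound 2, `CN(C)CC[C@H](CSc1ccccc1)Nc1ccc(S(=O)(=O)NC(=O)c2ccc(N3CCN(C(=O)Nc4ccccc4)CC3)cc2)cc1[N+](=O)[O-]`, 300 nM
compound 3, `CN(C)CC[C@H](CSc1ccccc1)Nc1ccc(S(=O)(=O)NC(=O)c2ccc(N3CCN(Cc4ccccc4S(C)(=O)=O)CC3)cc2)cc1[N+](=O)[O-]`, 4.6 nM

All three share the acylsulfonamide core and differ in the group attached to the saturated ring. In an assay on isolated protein for displacement of a labelled ligand from Apoptosis regulator Bcl-2 (Homo sapiens), read by fluorescence polarization (a lower number here means a stronger inhibitor, a higher number a weaker inhibitor), compound 3 gives 4.6 nM, which is the second strongest of the three numbers: compound 1 sits closer to it, and compound 2 lies far above it. Within the measured set the one single-point step is a 65-fold lower number from compound 2 to compound 3 (1.81 log units; beyond the scatter), a large change.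

Compound 4, `COc1ccc(-c2ccccc2CN2CCN(c3ccc(C(=O)NS(=O)(=O)c4ccc(N[C@H](CCN(C)C)CSc5ccccc5)c([N+](=O)[O-])c4)cc3)CC2)cc1`, is the next member. Relative to compound 3 the change is 4-methoxyphenyl in place of methylsulfonyl on an aromatic carbon; in words, 4-methoxyphenyl in place of methylsulfonyl on an aromatic carbon, ortho to a large group.

For the measured compounds named here, no measured step probes this exact exchange. Going by the values given here, the one step available concerns the whole substituent on the ring nitrogen rather than a group on the benzyl ring, so it bears on compound 4 only indirectly: it shows that this region tolerates, and indeed rewards, a bulky benzyl group. Compound 1 carries a 2-methylbenzyl at a comparable position and gives 1.4 nM, so a further aromatic ring here is not expected to be disruptive. The estimated step of a 1.5-fold lower number from compound 3 to compound 4 (0.19 log units; within the scatter) is therefore small, within or near the scatter. For compound 4 the expected value in this assay is 3 nM, with a range from 0.8 nM to 12 nM.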

Compound 4, inhibition constant: < 1 nM
Compound 4: only a limit was reported; the forecaster's own chance of this, stated with the estimate: 0%; middle value at least 3.0-fold (0.47 log units) from the limit.
By their numbers in this assay, from the lowest: compound 1; then compound 3; then compound 2. At a limit, below all of these: compound 4.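

Compound 4 is reported in this assay only as a limit, < 1 nM. Exchanging methylsulfonyl for 4-methoxyphenyl on an aromatic carbon, ortho to a large group, gives an at least 4.6-fold lower number from compound 3 to compound 4 (0.66 log units; beyond the scatter), so methylsulfonyl is not required for strong displacement of the labelled ligand, and this place on the benzyl ring accepts a further six-membered aromatic ring without any loss. The step fixes only the smallest possible size of the gain, and its full size remains unknown: the limit of < 1 nM in this assay, at which 1 of the 4 values shown sits.

Still open, on these data alone, is whether the gain belongs to the added aromatic ring or to its methoxy group, a question that a plain phenyl, a 4-fluorophenyl or a pyridine ring at this carbon would help to settle. Also open, as far as these compounds go, is how an amine or a carboxylic acid on the outer ring would read in this assay, and a further aryl group could be ranked against compound 4 only with a read-out that gives a number for compound 4 rather than a limit.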